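Series notes: aryl exchange on the shared core toward compound 4

A few compounds are considered here, and "the series" means these few. Any claim that something is new, unique, unknown or untested is made for them only; others in the source may bear on it.

Three measurements are in hand in a physicochemical assay for solubility, with a stated time of 18 h, at pH 7.4; a lower number here means a less soluble compound, a higher number a more soluble compound. Compound 1 `COc1ccc(F)cc1CNCCCNc1ccnc2cc(Cc3ccc(F)cc3Cl)ccc12` gives 4200 nM. Compound 2 `CN(C)c1cccc(Oc2ccc3c(NCCCNCc4ccco4)ccnc3c2)c1` gives 14500 nM, and compound 3 `Fc1ccc(Cc2ccc3c(NCCCNCc4ccco4)ccnc3c2)c(Cl)c1` gives 4200 nM. Compound 1 stands level with compound 3 at the digits shown, the two together the lowest of the three numbers; its nearest neighbour is compound 3, with no change at the digits printed from compound 1 to compound 3 (within the scatter), and its furthest is compound 2, which lies higher.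

Compound 4 `COc1ccc(F)cc1CNCCCNc1ccnc2cc(-c3cccc4ccccc34)ccc12` is not yet measured in this assay. It differs from compound 1 in one place: naphthalen-1-yl in place of 2-chloro-4-fluorobenzyl on an aromatic carbon.

Of the measured steps, the one that touches the same aromatic carbon of the shared core is a 3.5-fold lower number from compound 2 to compound 3 (0.54 log units; beyond the scatter), a modest drop when the phenoxy group gave way to the benzyl group. The step of no change at the digits printed from compound 1 to compound 3 (within the scatter) concerns the other end of the molecule and does not inform this change. Naphthalen-1-yl brings a second carbon-only aromatic ring with no donors or acceptors, so a further move downward in this assay, of modest size, is expected rather than none.

For compound 4 the estimate in this assay is 2000 nM, with a range from 700 nM to 6000 nM, corresponding to an expected step of a 2.1-fold lower number from compound 1 to compound 4 (0.32 log units; beyond the scatter).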

Compound 4, solubility: 32000 nM
Beside the measured number, compound 4's estimate is 16-fold (1.20 log units) below it; the whole stated range lies below it.
By their numbers in this assay, from the lowest: compounds 1 and 3 (each within the scatter of the next); then compound 2; then compound 4.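

In this assay, the step at this aromatic carbon is a 7.6-fold higher number from compound 1 to compound 4 (0.88 log units; beyond the scatter), so this position can move the number upward as well as downward. Among these compounds, the only earlier step at this carbon, a 3.5-fold lower number from compound 2 to compound 3 (0.54 log units; beyond the scatter), ran downward with a different pair of groups, and the new step shows that the direction depends on which groups are exchanged. Both 2-chloro-4-fluorobenzyl and naphthalen-1-yl count no hydrogen-bond donors or acceptors and no net charge, so a step of this size occurs here with those counts unchanged, and nothing measured in hand accounts for it.

On these data alone, the exchange changes several features together: it adds a second aromatic ring, removes the chlorine and fluorine, and replaces a benzyl group with an aryl group joined directly to the shared core, so the share of each remains open. Plain phenyl, naphthalen-2-yl or unsubstituted benzyl on the same aromatic carbon would help separate these features, and naphthalen-1-yl paired with the furan-2-yl end would test whether the step holds at the other end of the molecule.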